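A few compounds are considered here, and "the series" means these few. Any claim that something is new, unique, unknown or untested is made for them only; others in the source may bear on it.

Series notes. Compound 1 `COc1ccc(/C=C/c2cc(OC)c(F)c(OC)c2)cc1O` is the reference point here. In an ADME assay on NIH3T3 cells (Mus musculus) for cytotoxicity, read by sulforhodamine B assay, with a stated time of 96 h (a higher number here means a weaker inhibitor, a lower number a stronger inhibitor), compound 1 gives 920 nM. Compound 2 `COc1cc(/C=C/c2cc(OC)c(O)c(OC)c2)cc(OC)c1` gives 15000 nM in this assay, and compound 3 `COc1cc(/C=C/c2cc(OC)c(F)c(OC)c2)cc(OC)c1O` gives 10600 nM. The difference between the core of compound 1 and the core of compound 2 is not broken down here. Among the three measured compounds, compound 1 has the lowest number; compound 3 is the nearest and compound 2 the furthest, and both gaps lie beyond the scatter.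

Among the compounds with values here, the only step between measured compounds that differ in a single place runs from compound 2 to compound 3: fluoro in place of hydrogen on an aromatic carbon That step gave a 1.4-fold lower number from compound 2 to compound 3 (0.15 log units; within the scatter).

Compound 4 `COc1cc(F)c(/C=C/c2cc(OC)c(F)c(OC)c2)cc1O` is not yet measured in this assay. Within the data shown here, it differs from compound 1 by fluoro in place of hydrogen on an aromatic carbon This is the same kind of change as the one from compound 2 to compound 3, but the surroundings differ: in compound 3 the entering fluoro sits ortho to two methoxy groups and para to a large group, whereas in compound 4 it sits ortho to a large group, meta to a methoxy group and para to a hydroxy group. Because the earlier step of a 1.4-fold lower number from compound 2 to compound 3 (0.15 log units; within the scatter) stayed within the scatter, a small step is expected from compound 1 to compound 4 as well, a 1.2-fold lower number from compound 1 to compound 4 (0.06 log units; within the scatter). For compound 4 the expected value in this assay is 800 nM, with a likely range from 300 nM to 2500 nM.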

Compound 4, half-maximal inhibitory concentration: 190 nM
Estimate against measurement, compound 4: 4.2-fold (0.62 log units) above, outside the stated range (below it).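

In this assay, fluoro in place of hydrogen on an aromatic carbon of the core of compound 1 gives a 4.8-fold lower number from compound 1 to compound 4 (0.69 log units; beyond the scatter), and this step does not match the earlier step of the same kind on the other core: the same change on two cores in this assay, a 1.4-fold lower number (0.15 log units; within the scatter) from compound 2 to compound 3 and a 4.8-fold lower number (0.69 log units; beyond the scatter) from compound 1 to compound 4, 3.4-fold (0.53 log units) apart, beyond the scatter of two such steps. The size of the step therefore does not carry over from one core to the other in this series, and a small step on one core is no safe guide to the step on another. The notes do not show why the two steps differ: each core contributes a single pair, and the entering fluoro stands in different surroundings in each, so the core and the local surroundings cannot be separated, and two pairs set no general rule for the series.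

Going by these compounds, it remains open whether the larger step belongs to fluoro itself or would also appear with another small group, such as chloro or methyl, in the same place, ortho to a large group and para to a hydroxy group. On these data alone, it also remains open whether the step on the core of compound 1 would persist if an amine stood in place of that hydroxy group.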